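The source may report more compounds than this note shows. Statements on the series, on what has been measured and on what is new or still open speak of the compounds shown alone.

Series notes, an ADME assay on Vero cells (Chlorocebus sabaeus) for cytotoxicity, read by neutral red uptake, tested at 787 ug/mL; on this read-out higher numbers stand for a weaker effect at the one concentration tested and lower numbers for a stronger effect. Compound 1 `O=C1CSC(c2cccc(Cl)c2)N1CCN1CCCCC1` gives 31%; compound 2 `O=C1CSC(c2cccc(O)c2)N1CCN1CCCCC1` gives 60%; compound 3 `O=C1CSC(c2cccc(F)c2)N1CCN1CCCCC1` gives 27%. Compound 3 thus sits with compound 1, within the scatter, and below compound 2, the step of a number 33 percentage points lower from compound 2 to compound 3 (beyond the scatter) lying beyond it. Compound 4 `COc1cccc(C2SCC(=O)N2CCN2CCCCC2)c1` differs from compound 3 in one place: methoxy in place of fluoro on an aromatic carbon. Going by the values given here, no measured step swaps fluoro for methoxy. Among the compounds with values here, the closest comparisons are a number 4 percentage points lower from compound 1 to compound 3 (within the scatter), within the scatter, and a number 29 percentage points higher from compound 1 to compound 2 (beyond the scatter), a modest rise, hydroxy being the one group here that carries an acceptor, as methoxy does. For compound 4 a step in that same direction but smaller is expected, a number 13 percentage points higher from compound 3 to compound 4 (beyond the scatter). Compound 4 is estimated at 40%, with a range of 22% to 62%.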

Compound 4, a percentage reported as activity, at one concentration (the size of the read-out at that concentration, not a potency): 19%
Estimate against measurement, compound 4: 21 percentage points above, and the stated range ends above it.
By their numbers in this assay, from the lowest: compounds 4, 3 and 1 (each within the scatter of the next, the first and the last beyond it); then compound 2.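

In this assay methyl in place of hydrogen on the oxygen gives a number 41 percentage points lower from compound 2 to compound 4 (beyond the scatter) as its step, so the acceptor shared by hydroxy and methoxy does not keep the two groups together. Methoxy reads with fluoro, with a number 8 percentage points lower from compound 3 to compound 4 (within the scatter) as the step, but not with chloro, with a number 12 percentage points lower from compound 1 to compound 4 (beyond the scatter) as the step, and hydroxy alone stands far from the others. No evidence at hand accounts for these steps. 

On these data alone, whether ethoxy stays with methoxy remains open. So does whether an amine or a carboxylic acid on this aromatic carbon reads like hydroxy.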